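Cytotoxicity notes on the shared-core series

The source may report more compounds than this note shows. Statements on the series, on what has been measured and on what is new or still open speak of the compounds shown alone.

Measured so far:
Compound 1 `COc1ccc([C@H]2CC(=O)N(Cc3cccc([N+](=O)[O-])c3)C2)cc1OC1CCCC1`. In a functional assay on HEK293 cells (Homo sapiens) for cytotoxicity (on this read-out higher numbers stand for lower toxicity in this test and lower numbers for higher toxicity in this test), compound 1 gives > 10000 nM, a limit of the test.
Compound 2 `COc1ccc([C@H]2CC(=O)N(c3ccccc3C#N)C2)cc1OC1CCCC1`. In this assay compound 2 gives > 10000 nM, a limit of the test.
Compound 3 `COc1ccc([C@H]2CC(=O)N(c3cccc(NCC4CCOC4)c3)C2)cc1OC1CCCC1`. In this assay compound 3 gives > 10000 nM, a limit of the test.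

Compound 3 thus stands at the limit, as do both other compounds (the limit of > 10000 nM in this assay, at which 3 of the 3 values shown sit). The next compound is compound 4 `COc1ccc([C@H]2CC(=O)N(c3cccc(NS(=O)(=O)c4cccc(Cl)c4C)c3)C2)cc1OC1CCCC1`; the change from compound 3 is (3-chloro-2-methylphenyl)sulfonyl in place of (oxolan-3-yl)methyl on a nitrogen on an aromatic ring. For the measured compounds named here, the only measured step, a step that the two limits leave unreadable from compound 1 to compound 2, lies between two limits and concerns a different position, so no readable step bears on this change. Compound 4 is expected to stay near the limit, at 15000 nM, between 5000 nM and 50000 nM. The expected step that the limit leaves unreadable from compound 3 to compound 4 is thus none beyond the scatter.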

Compound 4, half-maximal cytotoxic concentration: > 10000 nM
Compound 4: only a limit was reported; the forecaster's own chance of this, stated with the estimate: 75%; the middle value is on the limit's open side.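

No step can be read from compound 3 to compound 4, as both values are limits: the limit of > 10000 nM in this assay, at which 4 of the 4 values shown sit. The compounds shown leave open whether any change on the shared core shifts the result in this assay at all.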